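From 4-Methoxyphenyl to Cyclopropyl on the Carbonyl

The source may report more compounds than this note shows. Statements on the series, on what has been measured and on what is new or still open speak of the compounds shown alone.

In a functional assay on HCT-116 cells (Homo sapiens) for inhibition, read by MTT assay, with a stated time of 48 h (on this read-out lower numbers stand for stronger inhibition and higher numbers for weaker inhibition), compound 1 `COc1ccc(-n2c(SCc3ccc(F)cc3)nnc2-c2cc(OC)c(OC)c(OC)c2)cc1` gives 38700 nM. Compound 2 `COc1ccc(-n2c(SCC(=O)c3ccccc3)nnc2-c2cc(OC)c(OC)c(OC)c2)cc1` reads > 60000 nM, which is a limit of the assay and not a number. Compound 3 `COc1ccc(C(=O)CSc2nnc(-c3cc(OC)c(OC)c(OC)c3)n2-c2ccc(OC)cc2)cc1` reads > 60000 nM, which is also a limit. Compound 3 therefore has no exact value and stands at the limit of > 60000 nM in this assay, at which 2 of the 3 values shown sit.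

Compound 4 `COc1ccc(-n2c(SCC(=O)C3CC3)nnc2-c2cc(OC)c(OC)c(OC)c2)cc1` carries cyclopropyl in place of 4-methoxyphenyl on a carbonyl carbon. Within the data shown here, no measured step makes this exact change. The closest evidence comes from the two compounds with a carbonyl in that chain, which show an at least 1.5-fold higher number from compound 1 to compound 2 (0.19 log units; that floor lies within the scatter) and an at least 1.5-fold higher number from compound 1 to compound 3 (0.19 log units; that floor lies within the scatter). Adding methoxy on the aromatic ring gives a step that the two limits leave unreadable from compound 2 to compound 3, so it adds no usable size. Compound 4 keeps the carbonyl, so the reading for compound 3 at > 60000 nM suggests that it too may reach the limit. The expected result is a number no higher from compound 3 to compound 4 (the limit leaves the size open), with no change expected beyond the scatter. For compound 4, the estimated value is 60000 nM, with an expected range of 28000 nM to 120000 nM.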

Compound 4, half-maximal inhibitory concentration: > 60000 nM
Compound 4: a limit, no number; the forecaster's own chance of this, stated with the estimate: 70%; the middle value lies on the limit itself.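

With cyclopropyl on the carbonyl carbon, 3 heavy atoms in place of the 8 of 4-methoxyphenyl, compound 4 reads > 60000 nM in this assay, which is a limit of the assay and not a number. Among these compounds, the only step that can be read is an at least 1.5-fold higher number from compound 1 to compound 4 (0.19 log units; that floor lies within the scatter), while the steps to compound 4 from compound 2 and from compound 3 cannot be read. Phenyl, 4-methoxyphenyl and now cyclopropyl on this carbonyl carbon all give the same reading, so a non-aromatic ring joins the aromatic ones there: the limit of > 60000 nM in this assay, at which 3 of the 4 values shown sit.

From the compounds shown here alone, how far compound 2, compound 3 and compound 4 each lie past that limit stays open, so these three groups cannot be ranked. Also open, going by these compounds, is whether an amine or a longer chain on the carbonyl carbon would give a measurable value.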